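Adding methylcarbamoyl to compound 3

The compounds below may be only part of what the source reports. "The series", "measured", "known", "first", "only" and "open" are said of these compounds alone.

Measured in a physicochemical assay for solubility, read by LC-MS, in phosphate buffer, with a stated time of 24 h, at pH 7.4; on this read-out higher numbers stand for higher solubility and lower numbers for lower solubility:
- Compound 1 `Cc1ncc(-c2cnc(NCc3c(F)ccc4c3CCO4)c3cn[nH]c(=O)c23)n1C`: 15000 nM
- Compound 2 `Cc1cc(-c2cnc(NCc3c(F)ccc4c3CCO4)c3cn[nH]c(=O)c23)n(C)n1`: 1000 nM
- Compound 3 `Cc1ncccc1-c1cnc(NCc2c(F)ccc3c2CCO3)c2cn[nH]c(=O)c12`: < 2000 nM, a limit of the assay and not a number

Compound 3 is known only through (the limit of < 2000 nM in this assay, at which 1 of the 3 values shown sits). Compound 4 `CNC(=O)c1ccc(-c2cnc(NCc3c(F)ccc4c3CCO4)c3cn[nH]c(=O)c23)c(C)n1` differs from it by methylcarbamoyl in place of hydrogen on an aromatic carbon, so that 2-methylpyridin-3-yl becomes 2-methyl-6-(methylcarbamoyl)pyridin-3-yl.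

The measured steps bear on this only indirectly, since each exchanges the whole group on the shared core. There is a 15-fold lower number from compound 1 to compound 2 (1.18 log units; beyond the scatter), and there is an at least 7.5-fold lower number from compound 1 to compound 3 (0.87 log units; beyond the scatter). Both lie beyond the scatter, while a step that the limit leaves unreadable from compound 2 to compound 3 cannot be read. None of them adds a group to a ring that is kept, so they give no direction for this change.

No shift beyond the scatter is expected, and the expected step is a step that the limit leaves unreadable from compound 3 to compound 4. For compound 4 the estimate is 1500 nM, with an expected range of 300 nM to 6000 nM.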

Compound 4, solubility: 19000 nM
Beside the measured number, compound 4's estimate is 13-fold (1.10 log units) below it, outside the stated range (above it).
By their numbers in this assay, from the lowest: compound 2; then compounds 1 and 4 (each within the scatter of the next).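

In this assay, adding methylcarbamoyl to the kept ring, on the aromatic carbon next to the ring nitrogen, gives an at least 9.5-fold higher number from compound 3 to compound 4 (0.97 log units; beyond the scatter), a reading of an added group that the exchanges of whole groups could not provide. The size of that step remains bounded, since compound 3 is known only through a limit and not a number: the limit of < 2000 nM in this assay, at which 1 of the 4 values shown sits. With this group in place, 2-methyl-6-(methylcarbamoyl)pyridin-3-yl shows a 19-fold higher number from compound 2 to compound 4 (1.28 log units; beyond the scatter) against 1,3-dimethyl-1H-pyrazol-5-yl, and a 1.3-fold higher number from compound 1 to compound 4 (0.10 log units; within the scatter) against 1,2-dimethyl-1H-imidazol-5-yl.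

Going by these compounds, whether a carboxylic acid, a nitrile or dimethylcarbamoyl on this carbon would give a step of like size stays open. So does the full size of the step, and whether methylcarbamoyl would act alike on the other groups.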